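The source may report more compounds than this note shows. Statements on the series, on what has been measured and on what is new or still open speak of the compounds shown alone.

Measured compounds in a functional assay on P388 cells (Mus musculus) for cytotoxicity, read by MTT assay, with a stated time of 72 h; a lower number here means a stronger inhibitor, a higher number a weaker inhibitor:
compound 1 `OCC#CCSc1cnc2ccccc2c1Cl` gives 2.4 ug/mL
compound 2 `OCC#CCSc1cnc2ccccc2c1[Se]CC#CCBr` gives 1.6 ug/mL
compound 3 `C#CC[Se]c1c(SCC#CCO)cnc2ccccc12` gives 2.5 ug/mL

Compound 3 has the highest of the three numbers in this assay, but all gaps are small: a 1.0-fold higher number from compound 1 to compound 3 (0.02 log units; within the scatter), and a 1.6-fold higher number from compound 2 to compound 3 (0.19 log units; within the scatter). The exchange of the chlorine atom for the six-atom group likewise moved little, a 1.5-fold lower number from compound 1 to compound 2 (0.18 log units; within the scatter). None of the three measured steps reaches beyond the scatter, so the series gives no sign yet that the substituent on this aromatic carbon matters in this assay.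

Compound 4 `C#CCSc1c(SCC#CCO)cnc2ccccc12` is not yet measured. It differs from compound 3 in one place: a group of 4 heavy atoms (3 carbon, 1 sulfur; no ring) in place of a group of 4 heavy atoms (3 carbon, 1 selenium; no ring), on an aromatic carbon. For the measured compounds named here, no measured pair exchanges sulfur for selenium on the same aromatic carbon, so the nearest guides are the steps that alter that carbon, a 1.0-fold higher number from compound 1 to compound 3 (0.02 log units; within the scatter) and a 1.5-fold lower number from compound 1 to compound 2 (0.18 log units; within the scatter), both within the scatter. A step of similar size and no particular direction is therefore expected, a 1.0-fold lower number from compound 3 to compound 4 (0.02 log units; within the scatter). Compound 4 is expected to give 2.4 ug/mL in this assay, with a range from 1.2 ug/mL to 5 ug/mL.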

Compound 4, concentration for 50% inhibition: 13.3 ug/mL
The estimate for compound 4 lay 5.5-fold (0.74 log units) below the measured number, and the stated range ends below it.
By their numbers in this assay, from the lowest: compounds 2, 1 and 3 (each within the scatter of the next); then compound 4.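

For the compounds shown here, the aromatic carbon opposite the ring nitrogen is not indifferent in this assay: with the chain otherwise unchanged, sulfur in place of selenium gives a 5.3-fold higher number from compound 3 to compound 4 (0.73 log units; beyond the scatter) and moves the series beyond the scatter for the first time. Propargylsulfanyl separates just as clearly from the bromine-bearing selenium chain, with an 8.3-fold higher number from compound 2 to compound 4 (0.92 log units; beyond the scatter) as the step, and from chloro, with a 5.5-fold higher number from compound 1 to compound 4 (0.74 log units; beyond the scatter) as the step, so compound 4 is the weakest of the four. Chloro and both selenium groups stay within the scatter of one another, so the sensitivity shows up only with this one sulfur group.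

Sulfur and selenium are compared only on this one chain, so it remains open whether the gap would hold with a longer chain or how an amine on this carbon would behave. Nothing measured here explains the gap.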